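Cytotoxicity notes on the shared core, compound 2 to compound 4

The source may hold more compounds than are shown below. What is called first, only, known or untested is meant among the compounds shown, and "the series" means these compounds.

In an ADME assay on cells (Homo sapiens) for cytotoxicity, read by resazurin assay, with a stated time of 5 days (a lower number here means that less compound is tolerated, a higher number that more compound is tolerated), compound 2 `O=S(=O)(Cc1nc(-c2ccc(Cl)nc2)c2sccc2n1)c1cccc(Cl)c1` gives 70000 nM, the highest of the two numbers shown. Compound 3 `COc1ccc(-c2nc(/C=C\c3cccc(Cl)c3)nc3ccsc23)cn1` gives 53000 nM, which lies within the scatter of the value for compound 2. Compound 1 `COc1ccc(-c2nc(COc3cccc(Cl)c3)nc3ccsc23)cn1` gives only a limit of this assay, > 50000 nM. One of the three values shown therefore rests at the limit of > 50000 nM in this assay, at which 1 of the 3 values shown sits. Compound 4 `COc1ccc(Nc2nc(CS(=O)(=O)c3cccc(Cl)c3)nc3ccsc23)cc1` has not yet been measured in this assay. Its difference from compound 2 is (4-methoxyphenyl)amino in place of 6-chloropyridin-3-yl on an aromatic carbon. For the measured compounds named here, no measured step between two compounds is available, so the expected step of a 1.3-fold lower number from compound 2 to compound 4 (0.10 log units; within the scatter) is taken to remain within the scatter, with no direction beyond it. Compound 4 is estimated at 55000 nM, between 20000 nM and 120000 nM.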

Compound 4, half-maximal cytotoxic concentration: 60000 nM
For compound 4 the middle estimate is 1.1-fold (0.04 log units) below the measured one; low and high end bracket the measured number.
By their numbers in this assay, from the lowest: compounds 3, 4 and 2 (each within the scatter of the next).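

For the compounds shown here, the first readable step at this position, a 1.2-fold lower number from compound 2 to compound 4 (0.07 log units; within the scatter), shows that in this assay (4-methoxyphenyl)amino can stand in place of 6-chloropyridin-3-yl on this aromatic carbon without a change beyond the scatter. The swap alters the ring, its link to the shared core and the hydrogen-bond donor count together, and this single step does not separate these changes. Compound 1 offers no number for comparison, only a limit: the limit of > 50000 nM in this assay, at which 1 of the 4 values shown sits.

On these data alone, whether a morpholine or a carboxylic acid on this carbon would move the number beyond the scatter stays open. Also open, as far as these compounds go, is whether the same swap behaves alike on other side chains of the shared core.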